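Aminothiazolopyrimidine TRPV1 antagonists: amine swap at the core

The compounds below may be only part of what the source reports. "The series", "measured", "known", "first", "only" and "open" are said of these compounds alone.

Measured compounds:
compound 1 `CSc1ccc(Nc2ncnc3sc(Nc4c(Cl)cccc4Cl)nc23)cc1` — 96 nM
compound 2 `Cc1nc(Nc2ccc(C(F)(F)F)c(Cl)c2)c2nc(Nc3c(Cl)cccc3Cl)sc2n1` — 3 nM
compound 3 `FC(F)(F)c1ccc(Nc2nc(N3CCCC3)nc3sc(Nc4c(Cl)cccc4Cl)nc23)cc1` — 12 nM

In a functional assay on HEK293 cells for antagonist activity at transient receptor potential cation channel subfamily V member 1 (Homo sapiens), read by calcium flux (on this read-out higher numbers stand for weaker inhibition and lower numbers for stronger inhibition), compound 3 stands second highest of the three numbers. Its nearest neighbour is compound 2, whose number is lower by a margin beyond the scatter; compound 1 lies furthest away, with a number higher by a margin also beyond the scatter. Among the measured compounds shown here, no single-point step between measured compounds is available for this series.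

Compound 4 `CC(C)CNc1nc(Nc2ccc(C(F)(F)F)cc2)c2nc(Nc3c(Cl)cccc3Cl)sc2n1` is unmeasured. It differs from compound 3 by isobutylamino in place of pyrrolidin-1-yl on an aromatic carbon. For the measured compounds named here, no measured pair isolates this change, so the expected step from compound 3 to compound 4 is estimated as none beyond the scatter, a 1.3-fold higher number from compound 3 to compound 4 (0.10 log units; within the scatter). Compound 4 is therefore expected to give about 15 nM in this assay, within a range of 5 nM to 45 nM.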

Compound 4, half-maximal inhibitory concentration: 2 nM
Beside the measured number, compound 4's estimate is 7.5-fold (0.88 log units) above it; measured number below the stated range.
By their numbers in this assay, from the lowest: compounds 4 and 2 (each within the scatter of the next); then compound 3; then compound 1.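

In this assay, the aromatic carbon between two ring nitrogen atoms proves sensitive to which amine it carries: isobutylamino in place of pyrrolidin-1-yl gives a 6.0-fold lower number from compound 3 to compound 4 (0.78 log units; beyond the scatter) in this single pair. The swap keeps the heavy-atom count while removing the ring and adding a hydrogen-bond donor, and these two changes cannot be separated here. Nothing available accounts for the step. Still open, as far as these compounds go, is whether the open chain or the amine hydrogen carries it; dimethylamino, with no ring and no such hydrogen, and cyclopentylamino, with a ring and that hydrogen, would separate the two.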